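The source may hold more compounds than are shown below. What is called first, only, known or untested is meant among the compounds shown, and "the series" means these compounds.

In a functional assay on Jurkat cells (Homo sapiens) for antiproliferative activity, read by MTT assay, with a stated time of 72 h (a higher number here means a weaker inhibitor, a lower number a stronger inhibitor), compound 1 `COc1cc(-n2ncnc2-c2ccc(C)cc2)cc(OC)c1OC` gives 300 nM. Compound 2 `COc1cc(-n2ncnc2-c2ccc(Cl)cc2)cc(OC)c1OC` gives > 10000 nM, which is a limit of the assay and not a number. Compound 2 therefore stands at the limit of > 10000 nM in this assay, at which 1 of the 2 values shown sits, so its true value is not known.

Compound 3 `COc1cccc(-c2ncnn2-c2cc(OC)c(OC)c(OC)c2)c1` keeps the shared core, but 3-methoxyphenyl takes the place of 4-chlorophenyl on an aromatic carbon: 3-methoxyphenyl in place of 4-chlorophenyl on an aromatic carbon.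

Going by the values given here, only one measured step bears on this change: an at least 33-fold higher number from compound 1 to compound 2 (1.52 log units; beyond the scatter). It is large and beyond the scatter, and it was made on the same phenyl group that is now replaced. A single change on this group can therefore move the number strongly. Among the compounds with values here, no measured compound carries a methoxy group on this phenyl, so the size of the new step remains uncertain. With the 4-chlorophenyl group gone, compound 3 is expected to move back toward compound 1, which gives 300 nM, without being assumed to match it.

The expected step in this assay is an at least 6.6-fold lower number from compound 2 to compound 3 (0.82 log units; beyond the scatter), toward a lower number. For compound 3 the estimated value is 1500 nM, with an expected range from 150 nM to 10000 nM.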

Compound 3, half-maximal inhibitory concentration: > 10000 nM
Compound 3: a limit, no number (the forecaster's own chance of this, stated with the estimate: 30%); middle value at least 6.6-fold (0.82 log units) from the limit.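

Replacing 4-methylphenyl with 3-methoxyphenyl on this aromatic carbon gives an at least 33-fold higher number from compound 1 to compound 3 (1.52 log units; beyond the scatter) in this assay. The earlier compounds showed only that 4-chlorophenyl could take the place of 4-methylphenyl with a large rise in the number; now a second, different group does the same, so of the three compounds shown, only the one with 4-methylphenyl, compound 1, gives a measurable value, 300 nM. The step between compound 2 and compound 3 cannot be read, because each of these two compounds gives a limit and not a number: the limit of > 10000 nM in this assay, at which 2 of the 3 values shown sit.

The step to compound 3 changes both the group carried by the phenyl and where it sits in the group's name, and the compounds shown do not separate these two changes, so which of them matters remains open. Also open, on these data alone, is whether a phenyl carrying an amine, or a longer chain such as ethyl in place of the methyl, would give a measurable value like that of compound 1 or would also end at a limit.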